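The compounds below may be only part of what the source reports. "The series", "measured", "known", "first", "only" and "open" are said of these compounds alone.

Compound 1 `CCN(CC)S(=O)(=O)c1ccc(S(=O)(=O)N2CCC[C@@H](C(=O)NC3CN(C(=O)C4CC4)C3)C2)cc1`: 2800 nM
Compound 2 `CCN1CC(NC(=O)[C@@H]2CCCN(S(=O)(=O)c3ccc(S(=O)(=O)N(CC)CC)cc3)C2)C1`: > 30000 nM

In a functional assay on MIA PaCa-2 cells (Homo sapiens) for inhibition, read by MTT assay, with a stated time of 7 days (a higher number here means a weaker inhibitor, a lower number a stronger inhibitor), compound 1 gives 2800 nM. For compound 2 the assay reports only (the limit of > 30000 nM in this assay, at which 1 of the 2 values shown sits), not a number. Among the compounds with values here, compound 2 therefore stands at the weak end of what has been measured, and the one measured step, an at least 10-fold higher number from compound 1 to compound 2 (1.02 log units; beyond the scatter), concerns a different part of the molecule. Compound 3 `CCN(CC)S(=O)(=O)c1ccc(S(=O)(=O)N2CCC[C@@H](C(=O)NC3COC3)C2)cc1` differs from compound 2 by oxetan-3-yl in place of 1-ethylazetidin-3-yl on an amide-type nitrogen. Within the data shown here, no measured step covers this change, so its direction is open. Compound 3 is expected to land near 12000 nM (range 2000 nM to 60000 nM), an estimated step of an at least 2.5-fold lower number from compound 2 to compound 3 (0.39 log units; beyond the scatter), with a real chance that only a limit is reported again.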

Compound 3, half-maximal inhibitory concentration: 2300 nM
For compound 3 the middle estimate is 5.2-fold (0.72 log units) above the measured one; the range from low to high includes it.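

Within the data shown here, putting oxetan-3-yl in place of 1-ethylazetidin-3-yl on the amide-type nitrogen gives an at least 13-fold lower number from compound 2 to compound 3 (1.11 log units; beyond the scatter), so the 1-(cyclopropylcarbonyl)azetidin-3-yl group of compound 1 is not the only group here that keeps activity. The change from that group to oxetan-3-yl gives a 1.2-fold lower number from compound 1 to compound 3 (0.09 log units; within the scatter), which leaves compound 1 and compound 3 level. The figure for compound 2 is a limit and not a number: the limit of > 30000 nM in this assay, at which 1 of the 3 values shown sits.

From the compounds shown here alone, whether a simple amine or a longer carbon chain on this nitrogen would match compound 3 remains open. The compounds shown also do not tell why compound 2 loses so much activity.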